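The source may report more compounds than this note shows. Statements on the series, on what has been measured and on what is new or still open speak of the compounds shown alone.

Measured compounds:
compound 1 `Cn1c(CN2CCC(c3ccccc3)CC2)nc2ccccc21` — 100 nM
compound 2 `Cn1c(CN2CCN(c3ccc(Cl)cc3F)CC2)nc2ccccc21` — 251 nM
compound 3 `Cn1c(CN2CCC(c3ccc(Cl)cc3)CC2)nc2ccccc21` — 63.1 nM

In a functional assay on HEK293 cells for antagonist activity at D(4) dopamine receptor (Homo sapiens), read by FLIPR (a higher number here means a weaker inhibitor, a lower number a stronger inhibitor), compound 1 stands second highest of the three numbers, giving 100 nM. Its nearest neighbour is compound 3, whose number is lower but within the scatter, while compound 2 gives a number higher by a margin beyond the scatter.

Compound 4 `Cn1c(CN2CCC(c3cccc(C(F)(F)F)c3)CC2)nc2ccccc21` differs from compound 1 by one change: trifluoromethyl in place of hydrogen on an aromatic carbon. Among the measured compounds shown here, only one measured step bears on this. Substitution of hydrogen by chloro on the aromatic carbon gave a 1.6-fold lower number from compound 1 to compound 3 (0.20 log units; within the scatter), a shift that stays within the scatter. The trifluoromethyl group of compound 4 is larger and sits at a different place on the same ring, so that step is only a loose guide, yet it suggests that decoration of this ring is tolerated without a large movement in this assay. The expectation is therefore a small step at most, probably no change beyond the scatter, with a slight lean toward a lower number. This corresponds to an expected step of a 1.3-fold lower number from compound 1 to compound 4 (0.10 log units; within the scatter). Compound 4 is thus estimated at 80 nM, with a likely range from 30 nM to 250 nM.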

Compound 4, inhibition constant: 251 nM
For compound 4 the middle estimate is 3.1-fold (0.50 log units) below the measured one, outside the stated range (above it).
By their numbers in this assay, from the lowest: compounds 3 and 1 (each within the scatter of the next); then compounds 2 and 4 (each within the scatter of the next).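

In this assay, trifluoromethyl on an aromatic carbon meta to a large group gives a 2.5-fold higher number from compound 1 to compound 4 (0.40 log units; beyond the scatter), the only single change shown that moves the number beyond the scatter. The chloro step, a 1.6-fold lower number from compound 1 to compound 3 (0.20 log units; within the scatter), stays within the scatter, so substitution on this ring is not neutral in every case, although the two steps differ in both the group and its place on the ring. No measurement shown here accounts for the trifluoromethyl step.

The compounds shown do not separate the effect of the group from that of its place, since chloro does not appear meta to a large group. Going by these compounds, it also remains open how a methyl group, a methoxy group, an amine or a carboxylic acid would fare at this position.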